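The source may hold more compounds than are shown below. What is called first, only, known or untested is meant among the compounds shown, and "the series" means these compounds.

Measured in a functional assay for inhibition, with Homo sapiens as the target; a lower number here means that less compound is needed, a higher number that more compound is needed for the effect:

Compound 1 `CC(=O)Nc1ccc(C2=NNC(=O)CC2)cc1` gives 1 ug/mL
Compound 2 `CCC(Cl)C(=O)Nc1ccc(C2=NNC(=O)CC2)cc1` gives 1.47 ug/mL

Only these two numbers exist so far, and they lie within the usual scatter of each other, so compound 2 cannot be told apart from compound 1 in this assay. The next compound to be measured is compound 3 `CC(C)(CCl)C(=O)Nc1ccc(C2=NNC(=O)CC2)cc1`. Compared with compound 2, it carries a group of 5 heavy atoms (4 carbon, 1 chlorine; no ring) in place of a group of 4 heavy atoms (3 carbon, 1 chlorine; no ring), on a carbonyl carbon. The entering group is 1-(chloromethyl)-1-methylethyl, and the exchange takes place on a carbonyl carbon whose other neighbour is an amide-type nitrogen.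

Within the data shown here, one measured step bears on this change: a 1.5-fold higher number from compound 1 to compound 2 (0.17 log units; within the scatter). It also exchanged the group on that carbonyl carbon, and it stayed within the scatter. Among the measured compounds shown here, a single step is thin evidence, and the data hold no measured compound with the entering group. Even so, the expectation is that this new exchange will also make little difference. The expected step is a 1.0-fold higher number from compound 2 to compound 3 (0.01 log units; within the scatter), which means none beyond the scatter. For compound 3 the estimated value is 1.5 ug/mL, with an expected range from 0.7 ug/mL to 3.2 ug/mL.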

Compound 3, half-maximal effective concentration: 11.4 ug/mL
The estimate for compound 3 lay 7.6-fold (0.88 log units) below the measured number; the measured number lies above the stated range.
By their numbers in this assay, from the lowest: compounds 1 and 2 (each within the scatter of the next); then compound 3.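

In this assay, the group on this carbonyl carbon turns out to matter, which the earlier exchange did not reveal: the result is a 7.8-fold higher number from compound 2 to compound 3 (0.89 log units; beyond the scatter), so more compound is needed for the same effect. Measured against the small methyl group of the starting compound, the entering 1-(chloromethyl)-1-methylethyl group gives an 11-fold higher number from compound 1 to compound 3 (1.06 log units; beyond the scatter), showing that a group with 4 heavy atoms was tolerated here while one with 5 heavy atoms was not, although both contain a chlorine and neither has a ring. The compounds shown offer no measured explanation for this sharp difference between two similar groups.

From the compounds shown here alone, it remains open whether the chlorine or the carbon framework of the entering group drives the step, and a tert-butyl group on the same carbonyl carbon, which has no chlorine, would help to separate the two. Also open, going by these compounds, is how other kinds of group would behave at this place, such as a longer unbranched chain, an amine or a carboxylic acid, and whether any of them would lower the number below that of compound 1.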